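This account rests on a few compounds, and the source may have more. Where it says the series, first, only, none or still open, it means among the compounds named here.

Working notes on the series, read in an ADME assay on MT4 cells (Homo sapiens) for cytotoxicity, read by MTT assay; a lower number here means that less compound is tolerated, a higher number that more compound is tolerated. Compound 2 `Cc1cc(C)cc(S(=O)(=O)c2c(C(=O)NCc3ccccc3N)[nH]c3ccc(Cl)cc23)c1` gives 46200 nM, the higher of the two numbers in hand, and compound 1 `Cc1cc(C)cc(S(=O)(=O)c2c(C(=O)Nc3ccc(O)cc3)[nH]c3ccc(Cl)cc23)c1` gives 18100 nM. Compound 3 `Cc1cc(C)cc(S(=O)(=O)c2c(C(=O)NCc3cccc(O)c3)[nH]c3ccccc23)c1` is reported as > 5190 nM, which is a limit of the assay and not a number. Among the compounds with values here, no step can be taken from compound 3.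

The next structure is compound 4 `Cc1cc(C)cc(S(=O)(=O)c2c(C(=O)Nc3ccc(CO)cc3)[nH]c3ccc(Cl)cc23)c1`. The change is 4-(hydroxymethyl)phenyl in place of 2-aminobenzyl on an amide-type nitrogen, with 4-(hydroxymethyl)phenyl in place of 2-aminobenzyl on an amide-type nitrogen. Within the data shown here, one measured step bears on this: a 2.6-fold higher number from compound 1 to compound 2 (0.41 log units; beyond the scatter), a modest step beyond the scatter, with 2-aminobenzyl in place of 4-hydroxyphenyl at that same nitrogen. Compound 4 gives up the same 2-aminobenzyl group and, like compound 1, carries a phenyl group on that nitrogen, although the two phenyl groups are not identical. The expectation therefore leans on compound 1 at 18100 nM, and a modest move towards a lower number in this assay is anticipated. Among the measured compounds shown here, the expected step is a 2.2-fold lower number from compound 2 to compound 4 (0.34 log units; beyond the scatter), similar in size to the one measured step and opposite in direction. For compound 4 the estimated value is 21000 nM, with an expected range of 9000 nM to 50000 nM.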

Compound 4, half-maximal cytotoxic concentration: 39600 nM
The estimate for compound 4 lay 1.9-fold (0.28 log units) below the measured number; measured number inside the range.
By their numbers in this assay, from the lowest: compound 1; then compounds 4 and 2 (each within the scatter of the next).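

In this assay, the exchange of 2-aminobenzyl for 4-(hydroxymethyl)phenyl on the amide-type nitrogen gives a 1.2-fold lower number from compound 2 to compound 4 (0.07 log units; within the scatter), so these two groups cannot be told apart at this position. With a phenyl group kept on that nitrogen, hydroxymethyl in place of hydroxy on an aromatic carbon gives a 2.2-fold higher number from compound 1 to compound 4 (0.34 log units; beyond the scatter), which shows that the substituent on the phenyl group alone can move the number by a modest step. Among compounds 1, 2 and 4, a phenyl group on the nitrogen therefore does not by itself go with the lower number: compound 1 stands apart, and compound 4 goes against any such reading.

On these data alone, it remains open whether an amine, a carboxylic acid or a longer chain in place of the hydroxymethyl group would keep the number with that of compound 4 or bring it towards that of compound 1. Compound 3 is reported only as a limit of the assay and gives no step, so the benzyl group carrying a hydroxy substituent stays unplaced in this comparison: the limit of > 5190 nM in this assay, at which 1 of the 4 values shown sits.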